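Swapping chloro for hydroxy on the para-substituted phenyl ring

The source may report more compounds than this note shows. Statements on the series, on what has been measured and on what is new or still open speak of the compounds shown alone.

Measured compounds:
- compound 1, `COc1ccc(-c2noc(-c3ccc(F)cc3)n2)cc1O`: 351000 nM
- compound 2, `COc1ccc(-c2noc(-c3ccc(Cl)cc3)n2)cc1OC1CCCC1`: 740 nM

In a functional assay on MIA PaCa-2 cells (Homo sapiens) for antiproliferative activity, read by MTT assay, with a stated time of 24 h (a higher number here means a weaker inhibitor, a lower number a stronger inhibitor), compound 1 gives 351000 nM, a weak result. Compound 2, which carries a cyclopentyloxy group on the shared core and a chloro group on the other ring, gives 740 nM in this assay, the lowest of the two numbers shown. The gap between compound 1 and compound 2 is well beyond the usual scatter, though the two differ in more than one place, so no single change can be credited for it.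

Compound 3, `COc1ccc(-c2noc(-c3ccc(O)cc3)n2)cc1OC1CCCC1`, is not yet measured. It differs from compound 2 in one place: hydroxy in place of chloro on an aromatic carbon. Among the measured compounds shown here, no single-change step between measured compounds is available to guide this, so the expectation rests on general experience with such swaps. A modest loss of potency is expected, with the step of a 4.1-fold higher number from compound 2 to compound 3 (0.61 log units; beyond the scatter) larger than the scatter. That expected step is far smaller than the gap between compound 1 and compound 2. Compound 3 is estimated to give 3000 nM in this assay, within the range 700 nM to 15000 nM.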

Compound 3, half-maximal inhibitory concentration: 480 nM
Compound 3: the middle estimate sits 6.3-fold (0.80 log units) above what was measured, outside the stated range (below it).
By their numbers in this assay, from the lowest: compounds 3 and 2 (each within the scatter of the next); then compound 1.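

In this assay, the step of a 1.5-fold lower number from compound 2 to compound 3 (0.19 log units; within the scatter) shows that chloro and hydroxy cannot be told apart on this aromatic carbon, para to a large group, when the cyclopentyloxy group is present on the shared core. The two substituents differ clearly in what is counted for them: chloro has no hydrogen-bond donor or acceptor, while hydroxy has one of each, yet this difference leaves no readable mark on the result in this pair. Nothing available explains why the two compounds read alike.

Going by these compounds, whether other groups at this place, such as an amine or a carboxylic acid, would also read like chloro and hydroxy remains open, and two substituents alone cannot settle how broadly this position accepts change. Also open, on these data alone, is how much of the wide gap between compound 1 and compound 2 belongs to the cyclopentyloxy group on the shared core and how much to the substituent on the other ring, since those two compounds differ in more than one place.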